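The source may report more compounds than this note shows. Statements on the series, on what has been measured and on what is new or still open speak of the compounds shown alone.

In an ADME assay on a cell-free system (plasma, Rattus norvegicus) for metabolic stability, read by LC-MS, with a stated time of 1 h, tested at 100 uM (on this read-out lower numbers stand for a less stable compound and higher numbers for a more stable compound), the three measured compounds gave:

Compound 1 `CC1=C(c2nc(-c3ccc(C#N)cc3)cs2)C(c2cc3ccccc3n2C)NC(=O)N1`: 95.6%
Compound 2 `CC1=C(c2nc(-c3ccc(C#N)cc3)cs2)C(c2ccc(F)nc2)NC(=O)N1`: 100%
Compound 3 `CC1=C(c2nc(-c3ccc(C#N)cc3)cs2)C(c2ccc(Br)nc2)NC(=O)N1`: 98.3%

Compound 2 stands at the top of the three numbers, but they are indistinguishable: a number 4.4 percentage points higher from compound 1 to compound 2 (within the scatter) and a number 1.7 percentage points lower from compound 2 to compound 3 (within the scatter) both lie within the scatter. Compound 4 `COc1ccc(C2NC(=O)NC(C)=C2c2nc(-c3ccc(C#N)cc3)cs2)cn1` differs from compound 2 in one place: methoxy in place of fluoro on an aromatic carbon. Among the measured compounds shown here, the only measured step at that carbon is the one from fluoro to bromo, a number 1.7 percentage points lower from compound 2 to compound 3 (within the scatter), which changed nothing beyond the scatter. For the measured compounds named here, no step with methoxy has been measured, so the expectation rests on that one step alone: no step beyond the scatter, a number 3 percentage points lower from compound 2 to compound 4 (within the scatter). Compound 4 is therefore estimated at 97%, within 88% to 100%.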

Compound 4, percent of the compound remaining: 100%
Compound 4: middle estimate off by 3 percentage points, on the low side; the measured number falls inside the stated range.
By their numbers in this assay, from the lowest: compounds 1, 3, 2 and 4 (each within the scatter of the next).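

Methoxy at this aromatic carbon gives no change at the digits printed from compound 2 to compound 4 (within the scatter) and a number 1.7 percentage points higher from compound 3 to compound 4 (within the scatter) in this assay so a third group, and the first here to carry a hydrogen-bond acceptor, leaves the read-out within the scatter. Exchanging the whole 1-methyl-1H-indol-2-yl for 6-methoxypyridin-3-yl gives a number 4.4 percentage points higher from compound 1 to compound 4 (within the scatter) and likewise stays within it. No measurement shown explains these numbers.

Still open, from the compounds shown here alone, is whether an amine or a carboxylic acid at this carbon would stay within the scatter. A longer chain, such as ethoxy in place of methoxy, is equally untested among the compounds shown.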